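Swapping a nitrile for chlorine on a thiophene-type core

The source may hold more compounds than are shown below. What is called first, only, known or untested is meant among the compounds shown, and "the series" means these compounds.

Of the compounds shown here, three share one core and have been measured in a functional assay on cells for agonist activity at Free fatty acid receptor 1 (Rattus norvegicus), read by FLIPR and calcium flux; on this read-out higher numbers stand for an effect only at larger amounts of compound and lower numbers for an effect already at smaller amounts. Compound 1 `CC#C[C@@H](Cc1nnn[nH]1)c1ccc(OCc2ccc3sc(F)c(-c4ccccc4C)c3c2)cc1` gives 14 nM. Compound 2 `CC#C[C@@H](Cc1nnn[nH]1)c1ccc(OCc2ccc3sc(C)c(-c4ccc(OCCOC)cc4C)c3c2)cc1` gives 32 nM. Compound 3 `CC#C[C@@H](Cc1nnn[nH]1)c1ccc(OCc2ccc3sc(C#N)c(-c4ccccc4C)c3c2)cc1` gives 19 nM, the second highest of the three numbers, though it sits within the scatter of both compound 1 and compound 2, so no order among them can be claimed. Among the compounds with values here, the one single-point step already measured, a 1.4-fold higher number from compound 1 to compound 3 (0.13 log units; within the scatter), shows that replacing fluoro with cyano at this position changed nothing beyond the scatter.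

Compound 4 `CC#C[C@@H](Cc1nnn[nH]1)c1ccc(OCc2ccc3sc(Cl)c(-c4ccccc4C)c3c2)cc1` is not yet measured. It differs from compound 3 by chloro in place of cyano on an aromatic carbon. Within the data shown here, the only step that bears on this change is the fluoro-to-cyano exchange at the same position, which stayed within the scatter; there is no measured step involving chloro. On that basis compound 4 is expected to show no shift beyond the scatter in this assay, with an expected step of a 1.1-fold lower number from compound 3 to compound 4 (0.05 log units; within the scatter). The estimate for compound 4 is therefore 17 nM, with a range from 8 nM to 36 nM.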

Compound 4, half-maximal effective concentration: 20 nM
Compound 4: the middle estimate sits 1.2-fold (0.07 log units) below what was measured; the range from low to high includes it.
By their numbers in this assay, from the lowest: compounds 1, 3, 4 and 2 (each within the scatter of the next, the first and the last beyond it).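

In this assay, chloro in place of cyano on the aromatic carbon next to the ring sulfur gives a 1.1-fold higher number from compound 3 to compound 4 (0.02 log units; within the scatter) and chloro in place of fluoro gives a 1.4-fold higher number from compound 1 to compound 4 (0.15 log units; within the scatter) and so both new steps stay within the scatter. Together with the earlier fluoro-to-cyano step, this means that fluoro, cyano and chloro can now all be compared directly at this position, and no one of them stands apart, even though cyano carries a triple bond and a hydrogen-bond acceptor that chloro lacks. No measured evidence accounts for this result.

Going by these compounds, whether the read-out stays this flat with an amine, a carboxylic acid or a longer chain at this position remains open. Compound 2 carries a methyl here but also differs on the aromatic group, so the effect of the methyl alone cannot be read.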